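This account rests on a few compounds, and the source may have more. Where it says the series, first, only, none or still open, it means among the compounds named here.

Working notes on the series. In a functional assay on MDA-MB-231 cells (Homo sapiens) for antiproliferative activity, read by fluorescence and resazurin assay, with a stated time of 72 h (a lower number here means a stronger inhibitor, a higher number a weaker inhibitor), compound 1 (`CC1(C)OB(c2ccc(CONC(=O)/C=C/c3cccc(S(=O)(=O)Nc4ccccc4)c3)cc2)OC1(C)C`) gives 303 nM and compound 2 (`CC1(C)OB(c2cccc(CONC(=O)/C=C/c3cccc(S(=O)(=O)Nc4ccccc4)c3)c2)OC1(C)C`) gives 2030 nM as the higher of the two numbers, a gap beyond the usual scatter that makes compound 2 the weaker inhibitor of the pair. Compound 3 (`O=C(/C=C/c1cccc(S(=O)(=O)Nc2ccccc2)c1)NOCc1cccc(B(O)O)c1`) is still to be measured. Going from compound 2 to compound 3 the structural change is a group of 3 heavy atoms (1 boron, 2 oxygen; no ring) in place of a group of 9 heavy atoms (6 carbon, 1 boron, 2 oxygen; one five-membered non-aromatic ring with 3 hetero atoms), on an aromatic carbon in which a group of 3 heavy atoms with no ring replaces the group with the five-membered non-aromatic ring, on an aromatic carbon of a six-membered aromatic ring of carbon only. For the measured compounds named here, no measured pair shows this change, so the expectation is loose: no step beyond the scatter in this assay and no firm direction. The expected step of a 1.1-fold lower number from compound 2 to compound 3 (0.05 log units; within the scatter) is small. For compound 3 the estimate is 1800 nM with 600 nM as the expected lower end and 5000 nM as the expected upper end.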

Compound 3, half-maximal inhibitory concentration: 2200 nM
Compound 3: middle estimate off by 1.2-fold (0.09 log units), on the low side; the measured number falls inside the stated range.
By their numbers in this assay, from the lowest: compound 1; then compounds 2 and 3 (each within the scatter of the next).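

In this assay, at the aromatic carbon meta to a large group, the group of 3 heavy atoms (1 boron, 2 oxygen; no ring) takes the place of the group with the five-membered non-aromatic ring, giving a 1.1-fold higher number from compound 2 to compound 3 (0.03 log units; within the scatter) as the first step read at this place. On this one pair, the two compounds cannot be told apart, even though the change removes the ring and goes from 0 to 2 hydrogen-bond donors. Nothing on hand explains this outcome.

On these data alone, whether the two groups also match at the ring position held in compound 1, which gives 303 nM in this assay, stays open. Also open, as far as these compounds go, is how a carboxylic acid or an amine would read at the place meta to a large group.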